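Trifluoromethyl in Place of Ethyl on a Diaryl Urea

A few compounds are considered here, and "the series" means these few. Any claim that something is new, unique, unknown or untested is made for them only; others in the source may bear on it.

Measured so far:
Compound 1 `Cc1cc(NC(=O)Nc2ccc(Cl)cc2)c2ccccc2n1` — in an ADME assay on BJ cells (Homo sapiens) for cytotoxicity, with a stated time of 72 h (on this read-out lower numbers stand for an effect already at smaller amounts and higher numbers for an effect only at larger amounts of compound), compound 1 gives > 25000 nM, which is a limit of the assay rather than a number.
Compound 2 `Cc1cc(NC(=O)Nc2ccc(C(C)(C)C)cc2)c2ccccc2n1` — in this assay compound 2 gives 20000 nM.
Compound 3 `CCc1ccc(NC(=O)Nc2cc(C)nc3ccccc23)cc1` — in this assay compound 3 gives > 25000 nM, again a limit of the assay and not a number.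

Compound 3 thus stands at the top of what this assay can report, the same ceiling at which compound 1 sits: the limit of > 25000 nM in this assay, at which 2 of the 3 values shown sit. Against compound 2 the step is an at least 1.2-fold higher number from compound 2 to compound 3 (0.09 log units; that floor lies within the scatter), and from compound 1 the step is a step that the two limits leave unreadable from compound 1 to compound 3. Among the measured compounds shown here, all three compounds share one core and differ only in the single group on the outer ring, and none of them shows a clear effect within the measured range.

Compound 4 `Cc1cc(NC(=O)Nc2ccc(C(F)(F)F)cc2)c2ccccc2n1` is not yet measured. It differs from compound 3 in one place: trifluoromethyl in place of ethyl on an aromatic carbon. For the measured compounds named here, no measured step swaps ethyl for trifluoromethyl, so the steps that bear on it are those that vary the same group among compounds 1, 2 and 3: an at least 1.2-fold lower number from compound 1 to compound 2 (0.09 log units; that floor lies within the scatter) and an at least 1.2-fold higher number from compound 2 to compound 3 (0.09 log units; that floor lies within the scatter), both inside the scatter. No movement beyond the scatter is therefore expected, and in this assay compound 4 is expected to show a number no higher from compound 3 to compound 4 (the limit leaves the size open). Compound 4 is estimated at 25000 nM, between 12000 nM and 50000 nM, with a good chance that only a limit is reported once more.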

Compound 4, half-maximal effective concentration in the BJ assay: > 25000 nM
Compound 4 gave a limit, no number; the forecaster's own chance of this, stated with the estimate: 65%; the middle value lies on the limit itself.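

Trifluoromethyl at this position joins chloro and ethyl at the top of what the BJ assay can report, so the steps that join two limits cannot be read, and the one readable step is an at least 1.2-fold higher number from compound 2 to compound 4 (0.09 log units; that floor lies within the scatter). The earlier compounds shown here did not show that a swap on this aromatic carbon can leave that read-out at its limit while another read-out moves. In a physicochemical assay for solubility, at pH 7.4 (on this read-out higher numbers stand for higher solubility and lower numbers for lower solubility), compound 3 gives 3300 nM and compound 4 gives 100 nM. Trifluoromethyl in place of ethyl thus comes with a large loss of solubility, one that the BJ assay alone would have left unseen: the measured solubility of compound 3, 3300 nM, and of compound 4, 100 nM, a 33-fold lower number (1.52 log units; beyond the scatter)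

A single pair carries this solubility result, so the compounds shown cannot tell whether it holds for other groups at this position, and the limits leave open where compounds 1, 3 and 4 would fall in the BJ assay if a number could be read. Nor do they show whether an amine or a carboxylic acid in place of trifluoromethyl would raise the number in the physicochemical assay while the compound stays at the limit in the BJ assay.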